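Taking the side chain off compound 2

This account rests on a few compounds, and the source may have more. Where it says the series, first, only, none or still open, it means among the compounds named here.

Measured in a functional assay for inhibition (a higher number here means a weaker inhibitor, a lower number a stronger inhibitor), as follows
- compound 1 `CC(C)(C)c1cc(-c2cc(=O)c3ccc(OCC(=O)O)cc3o2)cc(C(C)(C)C)c1O` gives 3000 nM; 100 nM (2 entries)
- compound 2 `CN(C)CCCOc1ccc2c(=O)cc(-c3cc(C(C)(C)C)c(O)c(C(C)(C)C)c3)oc2c1` gives 700 nM

For the measured compounds named here, compound 2 stands at 700 nM as its only number in this assay, with one further entry that carries no single number. Compound 3 `CC(C)(C)c1cc(-c2cc(=O)c3ccc(O)cc3o2)cc(C(C)(C)C)c1O` has hydrogen in place of 3-(dimethylamino)propyl on an oxygen on an aromatic ring. Going by the values given here, no measured pair shows this change, and compound 1 is itself widely spread (the several entries of compound 1 in this assay, 3000 nM; 100 nM (2 entries)), so the range stays broad. The expected 1.1-fold higher number from compound 2 to compound 3 (0.06 log units; within the scatter) lies within the scatter, with no direction favoured. For compound 3 the estimated value is 800 nM, with an expected range from 150 nM to 4000 nM.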

Compound 3, half-maximal inhibitory concentration: 1000 nM
The estimate for compound 3 lay 1.3-fold (0.10 log units) below the measured number; the range from low to high includes it.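

The change reads as a 1.4-fold higher number from compound 2 to compound 3 (0.15 log units; within the scatter) in this assay. On this oxygen, the 3-(dimethylamino)propyl group can therefore give way to hydrogen with no difference beyond the scatter, and compound 2 and compound 3 cannot be told apart. The amine-bearing chain is thus not needed for the inhibition seen with compound 3 in this assay.

From the compounds shown here alone, whether methoxy or a morpholine-bearing chain on this oxygen would read differently stays open. The place of the carboxylic acid of compound 1 also stays unsettled, its entries being widely spread: the several entries of compound 1 in this assay, 3000 nM; 100 nM (2 entries)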